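Fluoropyridyl for fluorophenyl exchange on two cores

The source may report more compounds than this note shows. Statements on the series, on what has been measured and on what is new or still open speak of the compounds shown alone.

Measured values in a functional assay on SW480 cells (Homo sapiens) for antiproliferative activity, read by sulforhodamine B assay, with a stated time of 48 h; a lower number here means a stronger inhibitor, a higher number a weaker inhibitor:

compound 1 `COc1ccc(/C=C/C(=O)c2ccccc2-c2ccc(F)cc2)cc1OC`: 570 nM
compound 2 `COc1ccc(/C=C/C(=O)c2ccccc2-c2ccc(F)nc2)cc1OC`: 1300 nM
compound 3 `COc1ccc(C(=O)/C=C/c2ccccc2-c2ccc(F)cc2)cc1O`: 340 nM

Compound 2 differs from compound 1 by 6-fluoropyridin-3-yl in place of 4-fluorophenyl on an aromatic carbon. That step is a 2.3-fold higher number from compound 1 to compound 2 (0.36 log units; beyond the scatter). Compound 3 carries a core different from that of compound 1; the difference between the two cores is not broken down here. Compound 3 has the lowest of the three numbers, but its gap to compound 1 lies within the scatter, so no order between those two is drawn; its gap to compound 2 lies beyond the scatter.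

Compound 4 `COc1ccc(C(=O)/C=C/c2ccccc2-c2ccc(F)nc2)cc1O` is not yet measured in this assay. It differs from compound 3 by 6-fluoropyridin-3-yl in place of 4-fluorophenyl on an aromatic carbon, the same change at the same place as between compound 1 and compound 2. For the measured compounds named here, only that one earlier instance is known, so the expectation rests on it alone. Going by the values given here, for compound 4 the step of a 2.3-fold higher number from compound 3 to compound 4 (0.36 log units; beyond the scatter) is expected, sized on the single known step of a 2.3-fold higher number from compound 1 to compound 2 (0.36 log units; beyond the scatter). Compound 4 is estimated at 780 nM in this assay, with an expected range from 400 nM to 1600 nM.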

Compound 4, half-maximal inhibitory concentration: 1600 nM
The estimate for compound 4 lay 2.1-fold (0.31 log units) below the measured number; measured number inside the range.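

In this assay, 6-fluoropyridin-3-yl in place of 4-fluorophenyl on the second core gives a 4.7-fold higher number from compound 3 to compound 4 (0.67 log units; beyond the scatter), the same direction as on the first core. For the compounds shown here, on these two cores, the change carries over in direction, and the two steps cannot be told apart in size: the same change on two cores in this assay, a 2.3-fold higher number (0.36 log units; beyond the scatter) from compound 1 to compound 2 and a 4.7-fold higher number (0.67 log units; beyond the scatter) from compound 3 to compound 4, 2.1-fold (0.31 log units) apart, within the scatter of two such steps This is only two instances of one exchange, so it supports a working expectation of a higher number on these two cores, but it sets no general rule for other cores and gives no reason for the shift.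

The compounds shown leave open whether the higher number follows from the ring nitrogen alone or depends on the fluorine that accompanies it, which a plain pyridin-3-yl or a pyridine ring carrying an amine in place of the fluorine would address. Also open, as far as these compounds go, is whether the same exchange holds on a core with other substituents on the far aromatic ring, such as a carboxylic acid, or in any other assay.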